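A few compounds are considered here, and "the series" means these few. Any claim that something is new, unique, unknown or untested is made for them only; others in the source may bear on it.

In a functional assay for inhibition, with Homo sapiens as the target (on this read-out lower numbers stand for an effect already at smaller amounts and higher numbers for an effect only at larger amounts of compound), compound 1 (`CC(=O)Nc1ccc(C2=NNC(=O)CC2)cc1`) gives 1 ug/mL. Within the data shown here, only one other compound has been measured so far: compound 2 (`CCCC(=O)Nc1ccc(C2=NNC(=O)CC2)cc1`) gives 1.44 ug/mL. These two values lie within the usual scatter of each other, so compound 1 cannot be ranked against compound 2.

The next structure is compound 3 (`CC(=O)Nc1ccc(C2=NNC(=O)C(C)C2)cc1`), which keeps the chain of compound 1 and alters the core instead: methyl in place of hydrogen on a saturated ring carbon. In words, a methyl takes the place of a hydrogen on a saturated ring carbon.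

Among the measured compounds shown here, no measured step covers a change at this ring carbon, so the evidence is indirect. For the measured compounds named here, the only measured step is on the chain, where an ethyl replaces a hydrogen on a saturated chain carbon bound to a carbonyl carbon. In this assay no shift beyond the scatter is expected, in either direction, since the step of a 1.4-fold higher number from compound 1 to compound 2 (0.16 log units; within the scatter) stayed inside it. That guidance is weak, so the range is kept wide.

The estimated value for compound 3 is 1 ug/mL, with an expected range from 0.3 ug/mL to 3.5 ug/mL. The expected change is no change at the digits printed from compound 1 to compound 3 (within the scatter).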

Compound 3, half-maximal effective concentration: 46.4 ug/mL
Compound 3: middle estimate off by 46-fold (1.67 log units), on the low side; the measured number lies above the stated range.
By their numbers in this assay, from the lowest: compounds 1 and 2 (each within the scatter of the next); then compound 3.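

This ring carbon proves far less tolerant than the chain: in this assay the methyl in place of hydrogen gives a 46-fold higher number from compound 1 to compound 3 (1.67 log units; beyond the scatter) on the saturated ring carbon, while the chain change gave a 1.4-fold higher number from compound 1 to compound 2 (0.16 log units; within the scatter) and so did not separate its two compounds. The position, two ring bonds from the ring atom that bears a large group, therefore matters for this read-out, and even a methyl there is enough to mean that a much larger amount of compound is needed for the same effect. Why this happens cannot be said, since no accompanying measurement speaks to the cause of this shift.

From the compounds shown here alone, what remains open is whether the rise in the number is specific to methyl or would also appear with another group on this ring carbon, such as a fluorine, a hydroxyl or an ethyl. Going by these compounds, it is also open whether the same methyl would shift the number to a similar extent on the longer chain of compound 2, which would show whether the two changes act independently of each other.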